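The source may report more compounds than this note shows. Statements on the series, on what has been measured and on what is new or still open speak of the compounds shown alone.

Measured compounds:
Compound 1 `CN(C)CCCn1nc(C2=C(c3cn(C)c4ccccc34)C(=O)NC2=O)c2cccnc21`: in a functional assay on SMMC-7721 cells (Homo sapiens) for antiproliferative activity, read by MTT assay, with a stated time of 48 h (on this read-out higher numbers stand for weaker inhibition and lower numbers for stronger inhibition), compound 1 gives > 100000 nM, which is a limit of the assay, not a number.
Compound 2 `Cn1cc(C2=C(c3nn(CCCN4CCCCC4)c4ncccc34)C(=O)N(c3ccccn3)C2=O)c2ccccc21`: in this assay compound 2 gives > 100000 nM, again a limit.
Compound 3 `CN1CCN(CCCn2nc(C3=C(c4cn(C)c5ccccc45)C(=O)NC3=O)c3cccnc32)CC1`: in this assay compound 3 gives > 100000 nM, again a limit.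

Compound 2 therefore stands only as a limit, with no measured number behind it; every value shown sits at the limit of > 100000 nM in this assay, at which 3 of the 3 values shown sit. Compound 4 `COc1ccc(N2C(=O)C(c3cn(C)c4ccccc34)=C(c3nn(CCCN4CCCCC4)c4ncccc34)C2=O)cc1` differs from compound 2 in one place: 4-methoxyphenyl in place of pyridin-2-yl on an amide-type nitrogen in a ring. For the measured compounds named here, the only step between measured compounds that differ in a single place, a step that the two limits leave unreadable from compound 1 to compound 3, concerns another part of the shared core, and its size cannot be read from two limits. Going by the values given here, no measured step bears on the change from compound 2 to compound 4, so neither a direction nor a size beyond the scatter can be drawn from the data. Compound 4 is expected to give 100000 nM, with a range from 20000 nM to 300000 nM. That estimate corresponds to an expected step of a number no higher from compound 2 to compound 4 (the limit leaves the size open).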

Compound 4, half-maximal inhibitory concentration: 1740 nM
Beside the measured number, compound 4's estimate is 57-fold (1.76 log units) above it, and the stated range ends above it.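

In this assay, putting 4-methoxyphenyl in place of pyridin-2-yl on the amide-type nitrogen in a ring gives an at least 57-fold lower number from compound 2 to compound 4 (1.75 log units; beyond the scatter), so this position can carry a large effect on the read-out. Going by these compounds, compound 2 stands only as a limit, so the full size of the step stays open. Compound 4 is the only compound shown with a measured number, and the others sit at one shared limit: the limit of > 100000 nM in this assay, at which 3 of the 4 values shown sit.

One pair cannot separate the part played by the methoxy group from that of the carbon-only ring, and a plain phenyl or a 4-hydroxyphenyl on the same nitrogen would help to tell them apart. On these data alone, it also remains open whether 4-methoxyphenyl would have a similar effect with dimethylamino or 4-methylpiperazin-1-yl in place of the piperidine at the end of the chain.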